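Series notes: methoxymethyl to 3-aminopropyl

The source may hold more compounds than are shown below. What is called first, only, known or untested is meant among the compounds shown, and "the series" means these compounds.

Measured in an ADME assay on HEp-2 cells (Homo sapiens) for cytotoxicity; a higher number here means that more compound is tolerated, a lower number that less compound is tolerated:
Compound 1 `CC(C)CCn1c(Cn2c(=O)n(C(C)C)c3ccccc32)nc2ccc(CN(C)C)cc21`: 26700 nM
Compound 2 `COCc1cccc2c1nc(Cn1c(=O)n(C(C)C)c3ccccc31)n2CCC(C)C`: 26700 nM

Compound 2 stands level with compound 1 at the digits shown, with no difference beyond the scatter. Within the data shown here, the two compounds do not differ in one place only, and no single-change step has been measured. Their values therefore give a level for the series, not the size of any one structural change.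

Compound 3 `CC(C)CCn1c(Cn2c(=O)n(C(C)C)c3ccccc32)nc2c(CCCN)cccc21` is the next compound to be read. It carries 2-aminoethyl in place of methoxy on a saturated chain carbon bound to an aromatic carbon. Cut one bond further out, the same difference reads methoxymethyl to 3-aminopropyl.

In this assay, no step beyond the scatter is the likeliest outcome, with a modest fall in the tolerated concentration as the main alternative. This expectation rests on compound 1 and compound 2 sharing one level, with compound 2 at 26700 nM. The expected change is a 1.3-fold lower number from compound 2 to compound 3 (0.13 log units; within the scatter). For compound 3 the estimated value is 20000 nM, with an expected range of 7000 nM to 50000 nM.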

Compound 3, half-maximal cytotoxic concentration: 2340 nM
Beside the measured number, compound 3's estimate is 8.5-fold (0.93 log units) above it, and the stated range ends above it.
By their numbers in this assay, from the lowest: compound 3; then compounds 1 and 2 (each within the scatter of the next).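

In this assay, among these compounds, replacing methoxy with 2-aminoethyl on a saturated chain carbon bound to an aromatic carbon gives an 11-fold lower number from compound 2 to compound 3 (1.06 log units; beyond the scatter) and provides the first single-change step. Among the compounds shown here, the shared level of the earlier compounds could not show this: the read-out at this position responds strongly to the group it carries. The change is not a single feature, as the entering group brings a nitrogen and a hydrogen-bond donor in place of the oxygen of methoxy and also extends the chain, and no measurement at hand assigns the step to any one of these differences.

Going by these compounds, whether the step follows the terminal amine or the longer chain stays open, and a 3-hydroxypropyl group or a plain butyl chain in the same place would separate the two. Also open, on these data alone, is how far the number moves with a shorter 2-aminoethyl chain, a tertiary amine such as 3-(dimethylamino)propyl, or a carboxylic acid at the chain end.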